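Adding a methylpiperazine to an amidine-linked phenyl

A few compounds are considered here, and "the series" means these few. Any claim that something is new, unique, unknown or untested is made for them only; others in the source may bear on it.

In a functional assay on MDA-MB-231 cells (Homo sapiens) for cytotoxicity, read by MTT assay, with a stated time of 72 h (a lower number here means a stronger inhibitor, a higher number a weaker inhibitor), compound 3 `COc1ccc(Cn2nc(-c3ccccc3)c3cc(C(=N)Nc4ccccc4)nc(NC4CCCCC4)c32)cc1` gives 3400 nM. Compound 1 `CN1CCN(c2ccc(NC(=N)c3cc4cn[nH]c4cn3)cc2)CC1` gives 47500 nM. Compound 2 `N=C(Nc1ccccc1)c1cc2cn[nH]c2cn1` gives > 50000 nM, which is a limit of the assay rather than a number. From compound 2 to compound 1 the change is 4-methylpiperazin-1-yl in place of hydrogen on an aromatic carbon, and the step is an at least 1.0-fold lower number from compound 2 to compound 1 (0.02 log units; that floor lies within the scatter). How the cores of compound 2 and compound 3 differ is not broken down here. Compound 4 `COc1ccc(Cn2nc(-c3ccccc3)c3cc(C(=N)Nc4ccc(N5CCN(C)CC5)cc4)nc(NC4CCCCC4)c32)cc1` carries the same change on the core of compound 3: 4-methylpiperazin-1-yl in place of hydrogen on an aromatic carbon. The earlier step rests on the limit (the limit of > 50000 nM in this assay, at which 1 of the 3 values shown sits), so it shows only a floor for any gain. The step from compound 3 to compound 4 is therefore expected to be small, about a 1.1-fold lower number from compound 3 to compound 4 (0.05 log units; within the scatter). Compound 4 is estimated at 3000 nM, within 1000 nM to 10000 nM.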

Compound 4, half-maximal inhibitory concentration: 129000 nM
For compound 4 the middle estimate is 43-fold (1.63 log units) below the measured one, outside the stated range (above it).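

In this assay, 4-methylpiperazin-1-yl in place of hydrogen on an aromatic carbon brings a 38-fold higher number from compound 3 to compound 4 (1.58 log units; beyond the scatter), a large loss of strength on this second core. The change therefore does not carry over from one core to the other as a fixed effect: the same change on two cores in this assay, an at least 1.0-fold lower number (0.02 log units; that floor lies within the scatter) from compound 2 to compound 1 and a 38-fold higher number (1.58 log units; beyond the scatter) from compound 3 to compound 4, at least 39-fold (1.60 log units) apart, beyond the scatter of two such steps

Compound 2 gives a limit rather than a number, so the true size of the first step stays unknown, and two cores do not show how any other core would respond: the limit of > 50000 nM in this assay, at which 1 of the 4 values shown sits.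

Going by these compounds, it remains open whether a morpholine or an unmethylated piperazine on that aromatic carbon would cost as much on the core of compound 3. The compounds shown also leave open which part of the core sets the difference between the two steps.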